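Replacing Isopropoxy with Chloro in Compound 1

The source may report more compounds than this note shows. Statements on the series, on what has been measured and on what is new or still open speak of the compounds shown alone.

Compound 1 `COc1ccc(C2=C(c3cc(OC)c(OC)c(OC)c3)C(=O)C(OC(C)=O)C2)cc1OC(C)C`: > 100 ug/mL (a limit)
Compound 2 `COc1ccc(C2=C(c3cc(OC)c(OC)c(OC)c3)C(=O)CC2O[SiH2]C(C)(C)C)cc1OC`: > 100 ug/mL (a limit)
Compound 3 `COc1ccc(C2=C(c3cc(OC)c(OC)c(OC)c3)C(=O)C(O[SiH2]C(C)(C)C)C2)cc1OC(C)C`: 7 ug/mL

In an ADME assay on L132 cells (Homo sapiens) for cytotoxicity, read by MTT assay, with a stated time of 72 h (a lower number here means a stronger inhibitor, a higher number a weaker inhibitor), compound 1 gives only a limit, > 100 ug/mL. Compound 1 sits at the limit of > 100 ug/mL in this assay, at which 2 of the 3 values shown sit. Compound 4 `COc1ccc(C2=C(c3cc(OC)c(OC)c(OC)c3)C(=O)C(OC(C)=O)C2)cc1Cl` differs from it in one place: chloro in place of isopropoxy on an aromatic carbon. Among the compounds with values here, the one measured step, an at least 14-fold lower number from compound 1 to compound 3 (1.15 log units; beyond the scatter), is large, but it lies on an oxygen on a saturated carbon, not on this aromatic carbon. It therefore offers no direct guide, and no large step is expected in this assay. The expected change is a number no higher from compound 1 to compound 4 (the limit leaves the size open). For compound 4 the estimate is 100 ug/mL, with an expected range from 30 ug/mL to 200 ug/mL.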

Compound 4, half-maximal inhibitory concentration: < 1 ug/mL
Compound 4 was reported as a limit; the forecaster's own chance of this, stated with the estimate: 65%; middle value at least 100-fold (2.00 log units) from the limit.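

In this assay, the aromatic carbon that carries isopropoxy proves to be a place of large change: chloro in place of isopropoxy gives an at least 100-fold lower number from compound 1 to compound 4 (2.00 log units; beyond the scatter). Within the data shown here, the earlier compounds showed a large step only on an oxygen on a saturated carbon, so this is the first such step on the aromatic ring. Compound 4 stands at a limit, so the full size of the step is unknown: the limit of < 1 ug/mL in this assay, at which 1 of the 4 values shown sits.

The compounds shown leave open whether an amine, a carboxylic acid or a longer chain on this aromatic carbon would follow chloro or isopropoxy.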